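The source may report more compounds than this note shows. Statements on the series, on what has been measured and on what is new or still open speak of the compounds shown alone.

Compound 2 `O=C(Nc1ccc(Cl)cc1CN1C(=O)c2ccccc2C1=O)c1ccccc1` gives in an assay on CHO cells for positive allosteric modulation of metabotropic glutamate receptor 5 (Homo sapiens), read by FLIPR (on this read-out higher numbers stand for an effect only at larger amounts of compound and lower numbers for an effect already at smaller amounts), only a limit of the assay, > 100000 nM, and no number. Compound 1 `O=C(Nc1ccc(Cl)cc1CN1C(=O)c2ccccc2C1=O)c1cccnc1` gives 35000 nM in this assay. Compound 3 `O=C(Nc1ccc(Cl)cc1CN1C(=O)c2ccccc2C1=O)c1ccccc1C(F)(F)F` differs from compound 2 by trifluoromethyl in place of hydrogen on an aromatic carbon. Within the data shown here, the single measured step, an at least 2.8-fold higher number from compound 1 to compound 2 (0.45 log units; beyond the scatter), concerns a different part of the molecule and ends at the limit (the limit of > 100000 nM in this assay, at which 1 of the 2 values shown sits), so no measured step bears on adding a trifluoromethyl group here. Compound 3 is therefore expected to stay near that limit, with an estimate of 100000 nM and a range from 20000 nM to 300000 nM. The expected step is a number no higher from compound 2 to compound 3 (the limit leaves the size open).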

Compound 3, half-maximal effective concentration: 5700 nM
Compound 3: the middle estimate sits 18-fold (1.24 log units) above what was measured, outside the stated range (below it).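

This place on the phenyl ring, ortho to a large group, clearly matters: in this assay, adding trifluoromethyl gives an at least 17-fold lower number from compound 2 to compound 3 (1.24 log units; beyond the scatter). The change also turns the order of the two rings around: the substituted phenyl now beats pyridin-3-yl, with a 6.1-fold lower number from compound 1 to compound 3 (0.79 log units; beyond the scatter). The exact size of the first step stays unknown because compound 2 gives only a limit of the assay: the limit of > 100000 nM in this assay, at which 1 of the 3 values shown sits.

On these data alone, what a methyl group, a methoxy group or a nitrile would do at this place remains open. So does whether trifluoromethyl on the pyridin-3-yl ring of compound 1 would bring a similar step.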